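Dropping the Hydroxy: What the Next Compound Should Show

The source may hold more compounds than are shown below. What is called first, only, known or untested is meant among the compounds shown, and "the series" means these compounds.

Of the compounds shown here, three built on one shared core have been tested in a functional assay, with a stated time of 30 min; a higher number here means a weaker inhibitor, a lower number a stronger inhibitor. Compound 1 `CCOc1ccc(/C=N/n2c(S)nnc2-c2cnccn2)cc1OC` gives 58800 nM, compound 2 `Oc1ccccc1/C=N/n1c(S)nnc1-c1cnccn1` gives 75900 nM, and compound 3 `Sc1nnc(-c2cnccn2)n1/N=C/c1ccc(Cl)cc1Cl` gives 81200 nM. Compound 2 sits among these numbers with both neighbours within the usual scatter of repeated measurements, so no real difference among the three can be claimed. Compound 4 `Sc1nnc(-c2cnccn2)n1/N=C/c1ccccc1` has not yet been measured; it differs from compound 2 by hydrogen in place of hydroxy on an aromatic carbon. Since compound 1 and compound 3 carry quite different groups on that ring yet stay within the scatter of compound 2, the step of a 1.1-fold higher number from compound 2 to compound 4 (0.02 log units; within the scatter) is expected to be small, with no direction beyond the scatter. Compound 4 is therefore estimated at 80000 nM, in a range from 35000 nM to 180000 nM.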

Compound 4, half-maximal inhibitory concentration: 52400 nM
Compound 4: middle estimate off by 1.5-fold (0.18 log units), on the high side; measured number inside the range.
By their numbers in this assay, from the lowest: compounds 4, 1, 2 and 3 (each within the scatter of the next).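

In this assay, replacing the hydroxy of the 2-hydroxyphenyl group with hydrogen gives a 1.4-fold lower number from compound 2 to compound 4 (0.16 log units; within the scatter). For the compounds shown here, this is the first comparison here that differs in only one place, and it shows that losing this hydroxy, with its hydrogen-bond donor and acceptor, causes no difference that can be told from the scatter. Nothing available explains this result. Still open, on these data alone, is whether a different group at this position, such as an amine or a carboxylic acid, would shift the number beyond the scatter.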